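Notes on the step from compound 3 to compound 4

The source may hold more compounds than are shown below. What is called first, only, known or untested is meant among the compounds shown, and "the series" means these compounds.

Measured so far in a functional assay on the whole organism (artery, strain albino) with Rattus norvegicus as the target, with a stated time of 240 min, at a dose of 10 mg/kg by the oral route; on this read-out higher numbers stand for more inhibition at the one dose given (going by the name of the read-out) and lower numbers for less inhibition:
compound 1 `CC1=C(C(=O)Nc2ccc(Br)cc2)C(c2ccc(Cl)cc2Cl)N=C(SCc2ccc(F)cc2)N1` gives 36.4%
compound 2 `CC1=C(C(=O)Nc2ccc([N+](=O)[O-])cc2)C(c2ccc(Br)cc2)N=C(SCc2ccccc2)N1` gives 27.7%
compound 3 `CC1=C(C(=O)Nc2ccc([N+](=O)[O-])cc2)C(c2cccc([N+](=O)[O-])c2)N=C(SCc2ccccc2)N1` gives 21%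

Compound 3 has the lowest of the three numbers. Its nearest neighbour is compound 2, and the step of a number 6.7 percentage points lower from compound 2 to compound 3 (within the scatter) lies within the scatter, so these two values set no order between them. Compound 1 stands further off, beyond the scatter, but it differs from compound 3 in more than one place, so no single change can be read from that pair.

Compound 4 `CC1=C(C(=O)Nc2ccc([N+](=O)[O-])cc2)C(c2cccc([N+](=O)[O-])c2)N=C(SCc2ccc(Cl)cc2)N1` differs from compound 3 in one place only: chloro in place of hydrogen on an aromatic carbon. Within the data shown here, no measured step touches this part of the molecule. Among the measured compounds shown here, the one step measured, from compound 2 to compound 3, changes another ring and stays within the scatter. Compound 1 also bears a halogen on its benzylsulfanyl group, yet it differs from compound 3 elsewhere as well, so its value cannot be set against compound 3 alone. With nothing directly comparable, the expectation is that the step of a number 2 percentage points higher from compound 3 to compound 4 (within the scatter) stays within the scatter, with no direction to call. Compound 4 is therefore expected near 23% in this assay, with a range from 12% to 36%.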

Compound 4, a percentage reported as inhibition, in the whole organism at one dose (the size of the read-out at that dose, not a potency): 20%
Compound 4: the middle estimate sits 3 percentage points above what was measured; measured number inside the range.
By their numbers in this assay, from the lowest: compounds 4, 3, 2 and 1 (each within the scatter of the next, the first and the last beyond it).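

In this assay, among these compounds, the step of a number 1 percentage points lower from compound 3 to compound 4 (within the scatter) is the only measured single change on the benzylsulfanyl group, and it sets no order between the two compounds. Chloro in place of hydrogen, on an aromatic carbon para to a large group, therefore gives no readable change at the one dose given while the rest of the molecule stays fixed. Among the compounds shown here, the earlier step touched a different ring, so this is the first reading for benzyl to 4-chlorobenzyl, and no measurement on hand bears on the reason for this result.

Still open, from the compounds shown here alone, is whether the change from phenyl to 4-chlorophenyl reads the same on other backgrounds: compound 1 also carries a halogen on its benzyl group but differs from compound 4 in other places, so its value cannot be assigned to that group. Also open, going by these compounds, is how a group of a different kind at this place, such as methoxy, an amine or a carboxylic acid on the benzyl ring, or a longer chain in place of benzyl, would read in this assay.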